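A few compounds are considered here, and "the series" means these few. Any claim that something is new, unique, unknown or untested is made for them only; others in the source may bear on it.

Two compounds of the series carry numbers in a functional assay on MCF7 cells (Homo sapiens) for antiproliferative activity, read by sulforhodamine B assay, with a stated time of 48 h, tested at 10 uM; a lower number here means less inhibition, a higher number more inhibition at the concentration tested (going by the name of the read-out). Compound 1 `CCCCCCCCCCCCCC[C@H](OCOC)[C@H](CN(C(C)C)C(C)C)NC(=O)OC(C)(C)C` gives 26.9%. Compound 2 `CCCCCCCCCCCCCC[C@H](O)[C@H](CN(CC)CC)NC(=O)OC(C)(C)C` gives 18.7% in this assay, the lower of the two numbers on hand, but its gap to compound 1 lies within the scatter, so the pair stands level rather than in any order. Among the measured compounds shown here, compound 1 and compound 2 differ from one another in two places, and no single step joins them, so their two values show only that both sit close together at this concentration.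

Compound 3 `CCCCCCCCCCCCCC[C@H](O)[C@H](CN(C(C)C)C(C)C)NC(=O)OC(C)(C)C` awaits measurement. It departs from compound 2 in one place: diisopropylamino in place of diethylamino on a saturated chain carbon, two bonds along the chain from an amide-type nitrogen. For the measured compounds named here, the entering group is the one already present in compound 1, whose number in this assay sits within the scatter of compound 2, so nothing in hand points to a step beyond the scatter in either direction. The expected step is small, a number 3.3 percentage points higher from compound 2 to compound 3 (within the scatter). Compound 3 is estimated at 22% in this assay, within a range from 6% to 40%.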

Compound 3, a percentage reported as inhibition, at one concentration (the size of the read-out at that concentration, not a potency): 25.3%
The estimate for compound 3 lay 3.3 percentage points below the measured number, within the range that was stated.
By their numbers in this assay, from the lowest: compounds 2, 3 and 1 (each within the scatter of the next).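

In this assay, the exchange of diethylamino for diisopropylamino on a saturated chain carbon, two bonds along the chain from an amide-type nitrogen, can now be read on its own: it gives a number 6.6 percentage points higher from compound 2 to compound 3 (within the scatter) and so leaves the two amines level at this concentration. The second change that separated the earlier pair can also be read on its own: hydrogen in place of methoxymethyl on an oxygen on a saturated carbon gives a number 1.6 percentage points lower from compound 1 to compound 3 (within the scatter) and so leaves the free hydroxyl and its methoxymethyl ether level as well. No measurement bearing on the cause of either step is available.

From the compounds shown here alone, both amines compared here are open-chain dialkylamino groups, so it remains open whether a cyclic amine such as piperidine or morpholine, or a primary amine in the same place, would give a step beyond the scatter. Also open are the replacement of the tert-butyl carbamate by a free amine and a shorter alkyl chain in place of the long one, and the single tested concentration gives no potency for any of these compounds.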